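The source may hold more compounds than are shown below. What is called first, only, known or untested is meant among the compounds shown, and "the series" means these compounds.

Working notes on the oxazolidinone series.

Compound 1 `O=C1O[C@@H](CN2CCCCC2)CN1c1ccc(-n2cc(-c3ccccn3)cn2)c(F)c1` is the reference point here. In a physicochemical assay for solubility, read by HPLC, with a stated time of 24 h (a higher number here means a more soluble compound, a lower number a less soluble compound), compound 1 gives 219000 nM, the highest of the three numbers recorded so far. Compound 2 `O=C1O[C@@H](CN2CCC(O)CC2)CN1c1ccc(-n2cc(-c3ccccn3)cn2)c(F)c1` carries a hydroxy on the piperidine and in this assay compound 2 gives 45900 nM; the change is a 4.8-fold lower number from compound 1 to compound 2 (0.68 log units; beyond the scatter). Compound 3 `COC[C@H]1CN(c2ccc(-n3cc(-c4ccccn4)cn3)c(F)c2)C(=O)O1` replaces the piperidine with a methoxy and compound 3 gives 36200 nM; the change is a 6.0-fold lower number from compound 1 to compound 3 (0.78 log units; beyond the scatter). Between compound 2 and compound 3 the change is a 1.3-fold lower number from compound 2 to compound 3 (0.10 log units; within the scatter), so these two cannot be ordered.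

Compound 4 `NC(=O)[C@H]1CN(c2ccc(-n3cc(-c4ccccn4)cn3)c(F)c2)C(=O)O1` is not yet measured. Its difference from compound 1 is carbamoyl in place of (piperidin-1-yl)methyl on a saturated ring carbon. Going by the values given here, the step that bears most directly on it is the one from compound 1 to compound 3, in which the piperidine was removed and a small oxygen-bearing group put in its place, with the outcome a 6.0-fold lower number from compound 1 to compound 3 (0.78 log units; beyond the scatter). Compound 4 also removes the piperidine, and the entering carbamoyl is again a small group; the step from compound 1 to compound 2 points the same way. A lowering of similar or somewhat greater size is therefore expected, an 8.8-fold lower number from compound 1 to compound 4 (0.94 log units; beyond the scatter). Compound 4 is estimated at 25000 nM, with a range from 8000 nM to 80000 nM.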

Compound 4, solubility: 27200 nM
Beside the measured number, compound 4's estimate is 1.1-fold (0.04 log units) below it, within the range that was stated.
By their numbers in this assay, from the lowest: compounds 4, 3 and 2 (each within the scatter of the next); then compound 1.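

With carbamoyl in place of (piperidin-1-yl)methyl on the saturated ring carbon next to the ring oxygen, this assay shows an 8.1-fold lower number from compound 1 to compound 4 (0.91 log units; beyond the scatter) and so gives a second replacement of the whole piperidine-bearing group that ends well short of compound 1. Carbamoyl differs from the earlier groups in having no ring and no chain carbon between it and the ring carbon, yet the result is a 1.3-fold lower number from compound 3 to compound 4 (0.12 log units; within the scatter) and a 1.7-fold lower number from compound 2 to compound 4 (0.23 log units; within the scatter) and so compounds 2, 3 and 4 cannot be ordered among themselves. Across these four compounds only compound 1 stands apart, and no measurement at hand accounts for that separation.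

The compounds shown do not separate the contribution of the piperidine ring from that of its nitrogen, and an open-chain amine such as dimethylaminomethyl at this ring carbon would address that question. On these data alone, how a carboxylic acid, or a longer chain ending in the same carbamoyl, would compare at this position also remains open.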